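A few compounds are considered here, and "the series" means these few. Any claim that something is new, unique, unknown or untested is made for them only; others in the source may bear on it.

Measured compounds in a functional assay on EKVX cells (Homo sapiens) for cytotoxicity, read by sulforhodamine B assay, with a stated time of 48 h; on this read-out higher numbers stand for weaker inhibition of growth and lower numbers for stronger inhibition of growth:

compound 1 `ClCc1ccc(Cn2cnc3nc(Cl)nc(Cl)c32)cc1`, 1900 nM
compound 2 `ClCc1ccccc1Cn1cnc2ncnc(Cl)c21`, 5370 nM
compound 3 `ClCc1ccccc1Cn1cnc2nc(Cl)nc(Cl)c21`, 1730 nM

Compound 1 and compound 3 are built from the same atoms joined differently; the difference between the two cores is not broken down here. In this assay the two give numbers that lie within the scatter of each other, so no order can be read from them. Compound 3 and compound 2 differ by hydrogen in place of chloro on an aromatic carbon. This change gave a 3.1-fold higher number from compound 3 to compound 2 (0.49 log units; beyond the scatter), a step beyond the scatter and a weakening of growth inhibition.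

Compound 4 `ClCc1ccc(Cn2cnc3ncnc(Cl)c32)cc1` has not yet been measured in this assay. It differs from compound 1 by hydrogen in place of chloro on an aromatic carbon. The surroundings of the change, as counted from the structures, read the same as for the pair of compound 3 and compound 2, so the change is the same one, carried onto the core of compound 1.

The step from compound 1 to compound 4 in this assay is expected to be a 3.0-fold higher number from compound 1 to compound 4 (0.48 log units; beyond the scatter), because a 3.1-fold higher number from compound 3 to compound 2 (0.49 log units; beyond the scatter) shows what this change did on the other core. Compound 4 is accordingly estimated at 5700 nM, with an expected range from 2600 nM to 12500 nM.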

Compound 4, concentration for 50% growth inhibition: 2230 nM
The estimate for compound 4 lay 2.6-fold (0.41 log units) above the measured number; the whole stated range lies above it.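

In this assay, hydrogen in place of the chloro group between the two ring nitrogen atoms gives a 1.2-fold higher number from compound 1 to compound 4 (0.07 log units; within the scatter), so on the core of compound 1 this change has no readable effect. Set beside the step on the other core, the two results cannot be told apart: the same change on two cores in this assay, a 3.1-fold higher number (0.49 log units; beyond the scatter) from compound 3 to compound 2 and a 1.2-fold higher number (0.07 log units; within the scatter) from compound 1 to compound 4, 2.6-fold (0.42 log units) apart, within the scatter of two such steps. This shows that the change is not proven to behave differently on the two cores, but it does not show that it carries over with a fixed size, since one step lies beyond the scatter and the other within it.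

Only chloro and hydrogen appear at this ring carbon in the compounds shown, so the effect of an amine or a methoxy group there remains open. Also open is what happens when an amine or a methoxy group replaces the other ring chloro group, or a hydroxymethyl group replaces the chloromethyl group, as all the compounds shown carry both of these unchanged.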